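Swapping the side chain: expected cytotoxicity of compound 4

The source may hold more compounds than are shown below. What is called first, only, known or untested is meant among the compounds shown, and "the series" means these compounds.

Compound 1 `Cc1nc(NCC2CCN(C)CC2)nc(N[C@@H]2C[C@H](CO)[C@@H](O)[C@H]2O)c1-c1nc2cnccc2s1` was tested in an ADME assay on cells (Homo sapiens) for cytotoxicity, read by polymerase chain reaction, with a stated time of 3 days (a lower number here means that less compound is tolerated, a higher number that more compound is tolerated), where compound 1 gives 25000 nM. Two close relatives sit at the same level: compound 2 `Cc1nc(Nc2ccccc2)nc(N[C@@H]2C[C@H](CO)[C@@H](O)[C@H]2O)c1-c1nc2cnccc2s1` gives 25000 nM and compound 3 `Cc1nc(NCc2ccccc2)nc(N[C@@H]2C[C@H](CO)[C@@H](O)[C@H]2O)c1-c1nc2cnccc2s1` gives 25000 nM, so compound 1 stands level with both. The change to compound 4 `Cc1nc(N[C@@H](C)c2ccccc2)nc(N[C@@H]2C[C@H](CO)[C@@H](O)[C@H]2O)c1-c1nc2cnccc2s1` is 1-phenylethyl in place of (1-methylpiperidin-4-yl)methyl on a nitrogen on an aromatic ring. The measured steps that bear on it all exchange the same side chain: no change at the digits printed from compound 1 to compound 2 (within the scatter), no change at the digits printed from compound 1 to compound 3 (within the scatter) and no change at the digits printed from compound 2 to compound 3 (within the scatter). None of them moved the half-maximal cytotoxic concentration beyond the scatter, so no step beyond the scatter is expected here either, no change at the digits printed from compound 1 to compound 4 (within the scatter). Compound 4 is therefore estimated at 25000 nM, with an expected range from 12000 nM to 50000 nM.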

Compound 4, half-maximal cytotoxic concentration: 25000 nM
The estimate for compound 4 equals the measured number at the digits printed; the measured number falls inside the stated range.
By their numbers in this assay, from the lowest: compounds 1, 2, 3 and 4 (each within the scatter of the next).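

In this assay, methyl in place of hydrogen on the saturated chain carbon gives no change at the digits printed from compound 3 to compound 4 (within the scatter), so this position now also holds a branched side chain with a defined stereocentre at the same level. The 1-phenylethyl group gives no change at the digits printed from compound 1 to compound 4 (within the scatter) and no change at the digits printed from compound 2 to compound 4 (within the scatter), which adds a third comparison with each earlier side chain. Nothing available explains this flat result. Still open, going by these compounds, is whether a carboxylic acid or a longer chain on this nitrogen would stay at this level.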